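Lengthening the Chain on a Sulfoxide Series

The source may report more compounds than this note shows. Statements on the series, on what has been measured and on what is new or still open speak of the compounds shown alone.

Compound 1 `CCCCCCSc1cc(-c2ccccc2)c(-c2ccccc2)nn1` and compound 2 `CCCCCCCSc1cc(-c2ccccc2)c(-c2ccccc2)nn1` share one core; compound 3 `CCCCCCCC[S+]([O-])c1cc(-c2ccccc2)c(-c2ccccc2)nn1` and compound 4 `CCCCCCCCC[S+]([O-])c1cc(-c2ccccc2)c(-c2ccccc2)nn1` share another, and the difference between the two cores is not broken down here. In an assay on microsomes from liver for inhibition of sterol O-acyltransferase 1 (Rattus norvegicus) (a lower number here means a stronger inhibitor, a higher number a weaker inhibitor), compound 1 gives 62000 nM, compound 2 gives 76000 nM and compound 3 gives 92000 nM. The change methyl in place of hydrogen on a saturated chain carbon, six bonds along the chain from a sulfur made a 1.2-fold higher number from compound 1 to compound 2 (0.09 log units; within the scatter). Compound 4 carries the same kind of change, (methyl in place of hydrogen on a saturated chain carbon, eight bonds along the chain from a sulfur), though the place differs: six bonds along the chain from a sulfur in one pair, eight bonds along the chain from a sulfur in the other. Because that earlier step a 1.2-fold higher number from compound 1 to compound 2 (0.09 log units; within the scatter) stayed within the scatter, the step to compound 4 is expected to be a 1.1-fold higher number from compound 3 to compound 4 (0.04 log units; within the scatter) in this assay. Compound 4 is therefore estimated at 100000 nM, likely between 50000 nM and 200000 nM.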

Compound 4, half-maximal inhibitory concentration: 87000 nM
Estimate against measurement, compound 4: 1.1-fold (0.06 log units) above, and the stated range covers the measured number.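

In this assay, the added methyl on the core of compound 3 gives a 1.1-fold lower number from compound 3 to compound 4 (0.02 log units; within the scatter). Set beside the same change on the core of compound 1, the two steps do not differ: the same change on two cores in this assay, a 1.2-fold higher number (0.09 log units; within the scatter) from compound 1 to compound 2 and a 1.1-fold lower number (0.02 log units; within the scatter) from compound 3 to compound 4, 1.3-fold (0.11 log units) apart, within the scatter of two such steps. This shows that on both cores, at these two places on the chain, the change left the number within the scatter; it does not show that a change with a real effect on one core would carry over to the other, and neither step here is large enough to test that.

Still open, going by these compounds, is whether a much longer chain, or a chain ending in an amine or a carboxylic acid, would move the number beyond the scatter. On these data alone, the effect of the difference between the two cores, taken alone, also remains open.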